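Ethyl to bromo on a growth-inhibiting benzamide

The source may report more compounds than this note shows. Statements on the series, on what has been measured and on what is new or still open speak of the compounds shown alone.

In a functional assay on HeLa cells (Homo sapiens) for inhibition, read by CCK-8 assay, with a stated time of 72 h, tested at 8 uM (on this read-out higher numbers stand for more inhibition of growth at the one concentration tested and lower numbers for less inhibition of growth), compound 3 (`CCc1ccc(SCc2ccc(C(=O)Nc3ccccc3N)cc2)cc1`) gives 71%, the highest of the three numbers available. Compound 1 (`COc1ccc(SCc2ccc(/C=C/C(=O)Nc3ccccc3N)cc2)cc1OC`) gives 21.9% and compound 2 (`Nc1ccccc1NC(=O)/C=C/c1ccc(CSc2ccc(Cl)cc2)cc1`) gives 17.3%, and both lie lower than compound 3 by more than the scatter.

Compound 4 (`Nc1ccccc1NC(=O)c1ccc(CSc2ccc(Br)cc2)cc1`) has not yet been measured. It departs from compound 3 at a single place: bromo in place of ethyl on an aromatic carbon. The 4-ethylphenyl thus becomes a 4-bromophenyl.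

For the measured compounds named here, no measured step makes this exchange directly. The nearest evidence is a number 4.6 percentage points lower from compound 1 to compound 2 (within the scatter), where 4-chlorophenyl stands in place of 3,4-dimethoxyphenyl on a sulfur. That step was measured on the core of compound 1, not on that of compound 3, so it offers only indirect guidance. Even so, it points to little change in this assay when this aromatic group is replaced.

The expected step is a number 6 percentage points lower from compound 3 to compound 4 (within the scatter), which stays within the scatter. For compound 4, the estimated value is 65%, with an expected range from 45% to 82%.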

Compound 4, percent growth inhibition at one concentration: 38.2%
Compound 4: middle estimate off by 26.8 percentage points, on the high side; the measured number lies below the stated range.
By their numbers in this assay, from the lowest: compounds 2 and 1 (each within the scatter of the next); then compound 4; then compound 3.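

On the core of compound 3, the group on the aromatic carbon para to a large group clearly matters in this assay: the exchange of ethyl for bromo gives a number 32.8 percentage points lower from compound 3 to compound 4 (beyond the scatter). For the compounds shown here, the only earlier step at this aromatic group, a number 4.6 percentage points lower from compound 1 to compound 2 (within the scatter), was measured on the core of compound 1 and changed more than one substituent, so it gave no sign of a shift this large. Nothing available accounts for the size of this drop.

With only ethyl and bromo shown at this place on this core, it remains open whether the number follows the ethyl group specifically or would also hold for a longer chain such as propyl, or for an amine. From the compounds shown here alone, it is also open whether the same exchange would move the number as far on the core of compound 1.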